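The source may hold more compounds than are shown below. What is called first, only, known or untested is meant among the compounds shown, and "the series" means these compounds.

Compound 1 `CCc1nc(-c2ccc(CNC(=O)c3c(Cl)c(CC)nn3C)cc2)no1`: > 50000 nM
Compound 2 `Cc1nn(C)c(C(=O)NCc2ccc(Oc3ccc(Cl)cc3)cc2)c1Cl`: 50000 nM

Both readings come from a toxicity assay on MCF-10A cells (Homo sapiens) for cytotoxicity; a lower number here means a stronger inhibitor, a higher number a weaker inhibitor. For compound 1 the reading is not a number but a limit of the assay, (the limit of > 50000 nM in this assay, at which 1 of the 2 values shown sits). Within the data shown here, compound 2 thus gives the only actual number here. Compound 3 `CCc1nn(C)c(C(=O)NCc2ccc(Oc3ccc(Cl)cc3)cc2)c1Cl` keeps all of compound 2 except for one change: methyl in place of hydrogen on a saturated chain carbon bound to an aromatic carbon. Among the measured compounds shown here, no measured pair here shows what such a change does in this assay, so the step of no change at the digits printed from compound 2 to compound 3 (within the scatter) is expected to stay within the usual scatter. Compound 3 is therefore estimated at 50000 nM, with a range from 25000 nM to 100000 nM.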

Compound 3, half-maximal inhibitory concentration: 8700 nM
The estimate for compound 3 lay 5.7-fold (0.76 log units) above the measured number; the measured number lies below the stated range.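

In this assay, the methyl-to-ethyl change is not silent: one added methyl on a saturated chain carbon bound to an aromatic carbon gives a 5.7-fold lower number from compound 2 to compound 3 (0.76 log units; beyond the scatter). With that ethyl present in both compounds, 4-chlorophenoxy in place of 5-ethyl-1,2,4-oxadiazol-3-yl gives an at least 5.7-fold lower number from compound 1 to compound 3 (0.75 log units; beyond the scatter). That step can only be read as a minimum, as the reading for compound 1 is a limit of the assay: the limit of > 50000 nM in this assay, at which 1 of the 3 values shown sits.

As far as these compounds go, whether a longer chain such as propyl would lower the number further remains open. So does what a hydroxymethyl or an amine would do on this carbon.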